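This account rests on a few compounds, and the source may have more. Where it says the series, first, only, none or still open, it means among the compounds named here.

Compound 1 `Cc1ccc(C2=NN(c3nc(-c4ccc([N+](=O)[O-])cc4)cs3)C(c3ccc(F)cc3)C2)s1`: 15.6 ug/mL
Compound 2 `CS(=O)(=O)c1ccc(-c2csc(N3N=C(c4ccc(Cl)s4)CC3c3ccc(F)cc3)n2)cc1`: > 500 ug/mL, a limit of the assay

In an ADME assay on NIH3T3 cells (Mus musculus) for cytotoxicity, read by XTT assay, with a stated time of 24 h (a lower number here means a stronger inhibitor, a higher number a weaker inhibitor), compound 1 gives 15.6 ug/mL. Compound 2 reaches only a limit of the assay at > 500 ug/mL. Among the two numbers shown, compound 2 therefore sits at the ceiling described by the limit of > 500 ug/mL in this assay, at which 1 of the 2 values shown sits. Among the compounds with values here, no step between measured compounds is available. Compound 3 `Cc1ccc(C2=NN(c3nc(-c4ccc(S(C)(=O)=O)cc4)cs3)C(c3ccc(F)cc3)C2)s1` differs from compound 2 by methyl in place of chloro on an aromatic carbon. For such a change no shift beyond the scatter is expected, in either direction. Compound 3 is thus expected to land near 500 ug/mL, within 150 ug/mL to 2000 ug/mL. The expected step is a number no higher from compound 2 to compound 3 (the limit leaves the size open), most likely again reported only as a limit.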

Compound 3, half-maximal inhibitory concentration: 374 ug/mL
Compound 3: the middle estimate sits 1.3-fold (0.13 log units) above what was measured; measured number inside the range.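

In this assay methylsulfonyl in place of nitro, with the 5-methylthiophen-2-yl kept, gives a 24-fold higher number from compound 1 to compound 3 (1.38 log units; beyond the scatter) and is the one change shown whose size can be read. For methyl in place of chloro on the five-membered ring, the compounds now give an at least 1.3-fold lower number from compound 2 to compound 3 (0.12 log units; that floor lies within the scatter) and nothing firmer. The true size of that step stays unread because compound 2 is only a limit: the limit of > 500 ug/mL in this assay, at which 1 of the 3 values shown sits.

Still open, as far as these compounds go, is whether an amine or a carboxylic acid at this place would shift the number. Also open, from the compounds shown here alone, is whether the step from nitro to methylsulfonyl holds with the 5-chlorothiophen-2-yl.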